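The source may hold more compounds than are shown below. What is called first, only, known or untested is meant among the compounds shown, and "the series" means these compounds.

Measured so far:
Compound 1, `CC(C)(C)OC(=O)N1CCC(Oc2ncnc3c2CCN3c2ccc(S(C)(=O)=O)cc2F)CC1`, gives 139% in a functional assay on CHO-K1 cells with Glucose-dependent insulinotropic receptor (Homo sapiens) as the target, read by a luciferase reporter, with a stated time of 5 h; on this read-out higher numbers stand for larger maximal responses and lower numbers for smaller maximal responses.
Compound 2, `COCCOC(=O)N1CCC(Oc2ncnc3c2CCN3c2ccc(S(C)(=O)=O)cc2F)CC1`, gives 86% in this assay.

Going by the values given here, compound 2 thus stands at the lower of the two numbers measured, and the one step joining them, a number 53 percentage points lower from compound 1 to compound 2 (beyond the scatter), shows how much the group on the oxygen of the carbamate can move the maximal response. Compound 3, `CSC(=O)N1CCC(Oc2ncnc3c2CCN3c2ccc(S(C)(=O)=O)cc2F)CC1`, is the next step from compound 2: methylsulfanyl in place of 2-methoxyethoxy on a carbonyl carbon. Among the compounds with values here, this is again a change at the same carbonyl, so the step from compound 1 to compound 2 is the only measured step that bears on it, and it was large. It ran from a bulkier group to a longer flexible one, whereas the new group is shorter than either, so its direction gives no firm guide. Compound 3 is therefore expected to stay near compound 2, with a change of a number 9 percentage points higher from compound 2 to compound 3 (within the scatter), and its estimated value in this assay is 95%, ranging from 60% to 135%.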

Compound 3, largest response reached (reported as percent of maximum), in percent of the reference or control that the assay uses: 135%
Compound 3: middle estimate off by 40 percentage points, on the low side; the measured number falls inside the stated range.
By their numbers in this assay, from the lowest: compound 2; then compounds 3 and 1 (each within the scatter of the next).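

Replacing 2-methoxyethoxy with methylsulfanyl on the carbonyl carbon gives a number 49 percentage points higher from compound 2 to compound 3 (beyond the scatter), so a low maximal response is not a general outcome of replacing tert-butoxy at this position. Comparing the two higher compounds directly gives a number 4 percentage points lower from compound 1 to compound 3 (within the scatter), so tert-butoxy is not needed for a high response, and a group joined to the carbonyl carbon through sulfur can serve as well. Nothing measured here explains why 2-methoxyethoxy behaves differently.

On these data alone, it remains open whether the lower number goes with the chain length of 2-methoxyethoxy or with its ether oxygen, a question that a plain butoxy group could help to separate. How an amine on the carbonyl carbon would behave also remains an open question.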